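A few compounds are considered here, and "the series" means these few. Any claim that something is new, unique, unknown or untested is made for them only; others in the source may bear on it.

Two compounds share one core and differ only in a group carried on a saturated chain carbon bound to an amine nitrogen. Compound 1 `CCc1ccc2[nH]c(=O)c(CN(Cc3ccc(C(C)(C)C)cc3)Cc3ccc(F)c(F)c3)cc2c1` bears a 3,4-difluorophenyl group there. In a toxicity assay on MDCK cells (Canis lupus familiaris) for cytotoxicity, read by crystal violet staining, with a stated time of 48 h (on this read-out lower numbers stand for higher toxicity in this test and higher numbers for lower toxicity in this test), compound 1 gives > 33000 nM, which is a limit of the test and not a number. Compound 2 `CCc1ccc2[nH]c(=O)c(CN(Cc3ccc(OC(F)F)cc3)Cc3ccc(C(C)(C)C)cc3)cc2c1` carries a 4-(difluoromethoxy)phenyl group in the same place. In this assay compound 2 gives > 5000 nM, again a limit rather than a number. The step that the two limits leave unreadable from compound 1 to compound 2 therefore cannot be read. Compound 2 thus stands at a limit, as do both values shown, namely the limit of > 33000 nM in this assay, at which 1 of the 2 values shown sits, and (the limit of > 5000 nM in this assay, at which 1 of the 2 values shown sits). Compound 3 `CCc1ccc2[nH]c(=O)c(CN(Cc3ccc(C(C)(C)C)cc3)[C@H](CO)c3ccccc3)cc2c1` is the next compound: 2-hydroxy-1-phenylethyl in place of 4-(difluoromethoxy)benzyl on an amine nitrogen. Going by the values given here, no measured step bears on this change, since the only step known is unreadable, so no size or direction can be taken from the measurements. The expectation rests on both known compounds sitting at limits, and compound 3 is estimated at 30000 nM, within a range from 5000 nM to 100000 nM, which would mean an expected step that the limit leaves unreadable from compound 2 to compound 3.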

Compound 3, half-maximal cytotoxic concentration: > 10000 nM
Compound 3 was reported as a limit (the forecaster's own chance of this, stated with the estimate: 70%); the middle value lies beyond the limit too.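

In this assay compound 3 gives > 10000 nM, which is a limit and not a number. Going by these compounds alone, all three values are limits, and no step among compound 1, compound 2 and compound 3 can be read. The compounds shown leave open whether these changes on the amine nitrogen alter the concentration that harms the cells, and by how much.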